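Chain-end swap at the saturated arm of the isoxazole sulfonamides

A few compounds are considered here, and "the series" means these few. Any claim that something is new, unique, unknown or untested is made for them only; others in the source may bear on it.

Compound 1 `CCc1onc(NS(=O)(=O)c2ccc(C(C)(C)C)cc2)c1Sc1cccc(OC)c1` and compound 2 `COc1cccc(Sc2c(NS(=O)(=O)c3ccc(C(C)(C)C)cc3)noc2CCCC#N)c1` share one core and differ only in the saturated chain. In an assay on A7R5 cells for displacement of a labelled ligand from Endothelin-1 receptor (Rattus norvegicus) (a lower number here means a stronger inhibitor, a higher number a weaker inhibitor), compound 1 gives 800 nM, and in this assay compound 2 gives 1300 nM. On these two numbers compound 2 cannot be set apart from compound 1: the step of a 1.6-fold higher number from compound 1 to compound 2 (0.21 log units; within the scatter) says that adding a cyanomethyl at that chain end left the read-out essentially unmoved.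

Compound 3 `COc1cccc(Sc2c(NS(=O)(=O)c3ccc(C(C)(C)C)cc3)noc2CCCCC=O)c1` is not yet measured. It carries the change (formylmethyl in place of cyano on a saturated chain carbon, three bonds along the chain from an aromatic carbon), so the chain grows by one carbon and the nitrile gives way to an aldehyde. Among the measured compounds shown here, the only measured step that bears on this is the chain extension from compound 1 to compound 2, which stayed within the scatter; no step in this set tests a nitrile against a carbonyl, so that part of the change is uncharted. On this basis the expected step of a 1.2-fold higher number from compound 2 to compound 3 (0.06 log units; within the scatter) is small, without a direction that the data can support, and the half-maximal inhibitory concentration of compound 3 in this assay is estimated at 1500 nM, within 500 nM to 4500 nM.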

Compound 3, half-maximal inhibitory concentration: 1400 nM
Beside the measured number, compound 3's estimate is 1.1-fold (0.03 log units) above it, and the stated range covers the measured number.
By their numbers in this assay, from the lowest: compounds 1, 2 and 3 (each within the scatter of the next).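

Among the compounds shown here, replacing 3-cyanopropyl with 4-formylbutyl gives, in this assay, a 1.1-fold higher number from compound 2 to compound 3 (0.03 log units; within the scatter) and is the first change in this set that tests the group at the far end of the chain rather than only adding to the chain. Read against the unextended chain, the 2-formylethyl in place of hydrogen gives a 1.8-fold higher number from compound 1 to compound 3 (0.24 log units; within the scatter) and so also stays unresolved, which means that neither the nitrile nor the aldehyde arm can be told apart from compound 1 in this read-out. The three compounds therefore form one flat group at this position, and no data are available to explain that flatness.

As far as these compounds go, whether this position stays as flat with an amine or a carboxylic acid at the end of the chain, or with a chain longer than 4-formylbutyl, remains open. Also open, from the compounds shown here alone, is whether a ring at this position would give a step beyond the scatter in this assay or whether the same flat reading would hold there too.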